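The source may hold more compounds than are shown below. What is called first, only, known or untested is meant among the compounds shown, and "the series" means these compounds.

Working notes on the series: compound 1 (`COc1cc(C(=O)NNC(=O)c2ccc3[nH]c(-c4ccc([N+](=O)[O-])s4)nc3c2)cc(OC)c1OC`), compound 2 (`COc1cccc(C(=O)NNC(=O)c2ccc3[nH]c(-c4ccc([N+](=O)[O-])o4)nc3c2)c1`) and compound 3 (`COc1ccc(C(=O)NNC(=O)c2ccc3[nH]c(-c4ccc([N+](=O)[O-])o4)nc3c2)cc1OC`) have been read in an ADME assay on Vero cells (Chlorocebus sabaeus) for inhibition, read by sulforhodamine B assay, with a stated time of 48 h; a lower number here means a stronger inhibitor of growth, a higher number a weaker inhibitor of growth. There compound 1 gives 31.3 ug/mL, compound 2 gives 31.3 ug/mL and compound 3 gives 62.5 ug/mL, which places compound 3 within the scatter of both others. Compound 4 (`COc1cc(C(=O)NNC(=O)c2ccc3[nH]c(-c4ccc([N+](=O)[O-])o4)nc3c2)cc(OC)c1OC`) differs from compound 3 by methoxy in place of hydrogen on an aromatic carbon. For the measured compounds named here, one measured step bears on this: the same kind of replacement gave a 2.0-fold higher number from compound 2 to compound 3 (0.30 log units; within the scatter). No change beyond the scatter is therefore expected in this assay. The estimated step is a 1.3-fold lower number from compound 3 to compound 4 (0.10 log units; within the scatter). Compound 4 is expected at 50 ug/mL, with an estimated range of 15.6 ug/mL to 125 ug/mL.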

Compound 4, concentration for 50% growth inhibition: 31.3 ug/mL
Compound 4: middle estimate off by 1.6-fold (0.20 log units), on the high side; measured number inside the range.
By their numbers in this assay, from the lowest: compounds 1, 2, 4 and 3 (each within the scatter of the next).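

In this assay methoxy in place of hydrogen, ortho to a methoxy group and meta to a methoxy group, gives a 2.0-fold lower number from compound 3 to compound 4 (0.30 log units; within the scatter) and so stays within the scatter at this position, as does the methoxy step a 2.0-fold higher number from compound 2 to compound 3 (0.30 log units; within the scatter). The pair compound 1 and compound 4 adds a reading of a different change: 5-nitrofuran-2-yl in place of 5-nitrothiophen-2-yl gives no change at the digits printed from compound 1 to compound 4 (within the scatter).

Going by these compounds, whether an amine or a carboxylic acid in place of this methoxy would move the number beyond the scatter remains open. No measurement available here explains these readings.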